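Three benzyl variants measured, a fourth one awaited

The source may hold more compounds than are shown below. What is called first, only, known or untested is meant among the compounds shown, and "the series" means these compounds.

Three compounds have been measured in an assay on isolated protein for inhibition of Amine oxidase [flavin-containing] A (Homo sapiens), read by fluorescence, with stated times of 15 min and 20 min; on this read-out higher numbers stand for weaker inhibition and lower numbers for stronger inhibition:
compound 1, `Cc1ccc(CN2CCC(CCNC(=O)/C=C/c3cc(C(C)(C)C)c(O)c(C(C)(C)C)c3)CC2)cc1`: 70100 nM
compound 2, `CC(C)(C)c1cc(/C=C/C(=O)NCCC2CCN(Cc3ccc(F)cc3)CC2)cc(C(C)(C)C)c1O`: 59600 nM
compound 3, `CC(C)(C)c1cc(/C=C/C(=O)NCCC2CCN(Cc3ccc(F)c(F)c3)CC2)cc(C(C)(C)C)c1O`: 64500 nM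

Compound 3 stands second highest of the three numbers. Its nearest neighbour is compound 2, with a 1.1-fold higher number from compound 2 to compound 3 (0.03 log units; within the scatter); its furthest is compound 1, with a 1.1-fold lower number from compound 1 to compound 3 (0.04 log units; within the scatter). Compound 4, `CC(C)(C)c1cc(/C=C/C(=O)NCCC2CCN(Cc3ccc(Br)cc3)CC2)cc(C(C)(C)C)c1O`, differs from compound 3 by 4-bromophenyl in place of 3,4-difluorophenyl on a saturated chain carbon bound to an amine nitrogen in a ring. Within the data shown here, the steps that bear on this change all sit at the same position of the shared core: a 1.2-fold lower number from compound 1 to compound 2 (0.07 log units; within the scatter), a 1.1-fold higher number from compound 2 to compound 3 (0.03 log units; within the scatter) and a 1.1-fold lower number from compound 1 to compound 3 (0.04 log units; within the scatter), every one within the scatter. Given that, no step beyond the scatter is expected in this assay, in either direction, for a 1.0-fold lower number from compound 3 to compound 4 (0.01 log units; within the scatter). Compound 4 is therefore estimated at 63000 nM, with a range from 30000 nM to 130000 nM.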

Compound 4, half-maximal inhibitory concentration: 73200 nM
Compound 4: middle estimate off by 1.2-fold (0.07 log units), on the low side, and the stated range covers the measured number.
By their numbers in this assay, from the lowest: compounds 2, 3, 1 and 4 (each within the scatter of the next).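

In this assay, bromo in the place of the earlier methyl and fluoro gives a 1.0-fold higher number from compound 1 to compound 4 (0.02 log units; within the scatter) and a 1.2-fold higher number from compound 2 to compound 4 (0.09 log units; within the scatter) and the change from 3,4-difluorophenyl to 4-bromophenyl gives a 1.1-fold higher number from compound 3 to compound 4 (0.05 log units; within the scatter) and so all three steps stay within the scatter. Across these four compounds, then, the benzyl group now carries a bromine without any step beyond the scatter appearing at this position. Nothing available explains why these numbers lie so close together. As far as these compounds go, whether an amine or a carboxylic acid on this aromatic ring would shift the number stays open. So does the effect of a longer chain in place of the benzyl group.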